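One Carbonyl Swap and a Much Shorter Half-Life

This account rests on a few compounds, and the source may have more. Where it says the series, first, only, none or still open, it means among the compounds named here.

Compound 1 `Cc1cn(C2CC(N=[N+]=[N-])C(COC(=O)NCCCO)O2)c(=O)[nH]c1=O` was tested in an ADME assay on the whole organism (serum) with Homo sapiens as the target; on this read-out higher numbers stand for a longer-lived compound and lower numbers for a shorter-lived compound. Compound 1 gives > 48 h, which is the limit of > 48 h in this assay, at which 1 of the 2 values shown sits, rather than a measured number. Compound 2 `Cc1cn(C2CC(N=[N+]=[N-])C(COC(=O)OCCCCO)O2)c(=O)[nH]c1=O` gives 0.5 h in this assay, and the change 4-hydroxybutoxy in place of (3-hydroxypropyl)amino on a carbonyl carbon brought an at least 96-fold lower number from compound 1 to compound 2 (1.98 log units; beyond the scatter). Compound 3 `Cc1cn(C2CC(N=[N+]=[N-])C(COC(=O)OCCCC(=O)O)O2)c(=O)[nH]c1=O` differs from compound 1 by 3-carboxypropoxy in place of (3-hydroxypropyl)amino on a carbonyl carbon, again an oxygen-linked chain replacing the amino group on that carbonyl carbon, so the measured step bears directly on it. A comparably large drop is expected, an at least 80-fold lower number from compound 1 to compound 3 (1.90 log units; beyond the scatter), so compound 3 is estimated at 0.6 h, within 0.15 h to 3 h.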

Compound 3, half-life: 13 h
For compound 3 the middle estimate is 22-fold (1.34 log units) below the measured one; measured number outside the range, above it.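

In this assay an oxygen-linked chain on the carbonyl carbon does not settle the number by itself: the end of the chain counts as well, with carboxy in place of hydroxymethyl bringing a 26-fold higher number from compound 2 to compound 3 (1.41 log units; beyond the scatter). Leaving (3-hydroxypropyl)amino for 3-carboxypropoxy still brings an at least 3.6-fold lower number from compound 1 to compound 3 (0.56 log units; beyond the scatter). Compound 1 stands at a limit and not at a number: the limit of > 48 h in this assay, at which 1 of the 3 values shown sits.

As far as these compounds go, what stays open is how an amine at the chain end would fare on the oxygen-linked chain. Also open, from the compounds shown here alone, is what a carboxylic acid at the end of the amino-linked chain, or a longer chain, would do.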